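The compounds below may be only part of what the source reports. "The series", "measured", "known", "first", "only" and "open" are said of these compounds alone.

Compound 1 `CS/C(=N\C(=O)c1ccno1)NC(=O)c1ccno1` belongs to a small set of bis-acylated derivatives on a shared core. In a functional assay on MCF7 cells (Homo sapiens) for cytotoxicity, read by MTT assay, with a stated time of 72 h (on this read-out higher numbers stand for lower toxicity in this test and lower numbers for higher toxicity in this test), compound 1 gives > 100000 nM, which is a limit of the assay and not a number. Compound 2 `C[Se]/C(=N\C(=O)c1ccco1)NC(=O)c1ccco1` gives > 100000 nM in this assay, again a limit rather than a number. Compound 3 `C[Se]/C(=N\C(=O)c1cccs1)NC(=O)c1cccs1` gives > 100000 nM in this assay, also a limit. Compound 1 therefore stands at the limit of > 100000 nM in this assay, at which 3 of the 3 values shown sit; no measured step between any two compounds can be drawn, and nothing on the numbers shown separates compound 1 from compound 2 or compound 3.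

Compound 4 `O=C(/N=C(/NC(=O)c1ccno1)[Se]Cc1ccccc1)c1ccno1` has not yet been measured in this assay. It differs from compound 1 by a group of 8 heavy atoms (7 carbon, 1 selenium; one six-membered aromatic ring of carbon only) in place of a group of 2 heavy atoms (1 carbon, 1 sulfur; no ring), on a carbon with a double bond to nitrogen. For the measured compounds named here, with every measured value sitting at the limit, there is no measured step from which a size for this change could be read. The expected step from compound 1 to compound 4 is a number no higher from compound 1 to compound 4 (the limit leaves the size open), which is to say none beyond the scatter, with the result most likely again reported only as a limit. For compound 4 the expected value in this assay is 100000 nM, with a range from 30000 nM to 300000 nM.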

Compound 4, concentration lethal to 50% of the cells: > 100000 nM
Compound 4 was reported as a limit (the forecaster's own chance of this, stated with the estimate: 75%); the middle value sits exactly at the limit.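

For the compounds shown here, the step between compound 1 and compound 4 cannot be read, so this result adds no new step to the series: the limit of > 100000 nM in this assay, at which 4 of the 4 values shown sit.

The compounds shown leave open how far any of them lies beyond that limit in this assay, and whether the change on the carbon with a double bond to nitrogen shifts the read-out at all.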